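Para-substituent switch on the anilide ring of compound 1

The source may report more compounds than this note shows. Statements on the series, on what has been measured and on what is new or still open speak of the compounds shown alone.

Measured compounds:
compound 1 `CN(C)C(=O)c1cc2cnc(Nc3ccc(NC(=O)C4(C(=O)Nc5ccc(Cl)cc5)CC4)cc3)nc2n1C1CCCC1` — 101%
compound 2 `CN(C)C(=O)c1cc2cnc(Nc3ccc(NC(=O)C4(C(=O)Nc5cccc(C(F)(F)F)c5)CC4)cc3)nc2n1C1CCCC1` — 89.2%
compound 3 `CN(C)C(=O)c1cc2cnc(Nc3ccc(NC(=O)C4(C(=O)Nc5cccc(Br)c5)CC4)cc3)nc2n1C1CCCC1` — 92.2%

In a functional assay on A549 cells (Homo sapiens) for inhibition, read by CCK-8 assay, with a stated time of 72 h, tested at 10 uM (on this read-out higher numbers stand for more inhibition of growth at the one concentration tested and lower numbers for less inhibition of growth), compound 1 gives the highest of the three numbers; compound 3 sits nearest, with a number 8.8 percentage points lower from compound 1 to compound 3 (within the scatter), and compound 2 sits furthest, with a number 11.8 percentage points lower from compound 1 to compound 2 (beyond the scatter). The two meta-substituted anilides differ from each other by a number 3 percentage points higher from compound 2 to compound 3 (within the scatter).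

Compound 4 `CN(C)C(=O)c1cc2cnc(Nc3ccc(NC(=O)C4(C(=O)Nc5ccc(C(F)(F)F)cc5)CC4)cc3)nc2n1C1CCCC1` is not yet measured. It differs from compound 1 by trifluoromethyl in place of chloro on an aromatic carbon: the chloro leaves and a trifluoromethyl enters, on an aromatic carbon of a six-membered aromatic ring of carbon only, para to a large group.

Among the measured compounds shown here, two measured steps bear on this. The entry of a trifluoromethyl group elsewhere on the same ring, seen in a number 11.8 percentage points lower from compound 1 to compound 2 (beyond the scatter), cost a modest amount beyond the scatter; the other halogen swap, a number 8.8 percentage points lower from compound 1 to compound 3 (within the scatter), stayed within the scatter. Neither tests a trifluoromethyl at the place compound 4 carries it. A small loss in this assay is therefore expected, at the edge of the scatter, so that compound 4 is expected to give 93% (range 82% to 103%), an expected step of a number 8 percentage points lower from compound 1 to compound 4 (within the scatter).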

Compound 4, percent growth inhibition at one concentration: 87.9%
The estimate for compound 4 lay 5.1 percentage points above the measured number; low and high end bracket the measured number.
By their numbers in this assay, from the lowest: compounds 4, 2, 3 and 1 (each within the scatter of the next, the first and the last beyond it).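

In this assay, trifluoromethyl now has a direct test at the place of the chloro, para to a large group, and the step is beyond the scatter (a number 13.1 percentage points lower from compound 1 to compound 4 (beyond the scatter)). The place of the trifluoromethyl on the ring makes no difference that this read-out can separate (a number 1.3 percentage points lower from compound 2 to compound 4 (within the scatter)), so the 4-(trifluoromethyl)phenyl and 3-(trifluoromethyl)phenyl compounds cannot be told apart. The 4-(trifluoromethyl)phenyl compound also stays within the scatter of the 3-bromophenyl compound (a number 4.3 percentage points lower from compound 3 to compound 4 (within the scatter)), and since compound 3 is itself within the scatter of compound 1, no sharp divide separates the chloro compound from the other three.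

Nothing at hand gives a reason for the loss on trifluoromethyl entry. As far as these compounds go, whether an amine or a carboxylic acid at this place would hold the number of compound 1 remains open.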